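The compounds below may be only part of what the source reports. "The series", "measured", "known", "first", "only" and "open" are said of these compounds alone.

Two measured compounds share one core. Compound 1, `Cc1nc(-c2ccccc2C(C)C)nc(NCc2ccc(-c3cccnc3)cc2)c1C`, gives 120 nM in an assay on a protein complex for inhibition of ubiquitin carboxyl-terminal hydrolase 1/WD repeat-containing protein 48 (Homo sapiens), read by fluorescence; a lower number here means a stronger inhibitor, a higher number a weaker inhibitor. Compound 2, `CC(C)c1ccccc1-c1ncc(F)c(NCc2ccc(-c3cccnc3)cc2)n1`, gives 110 nM in this assay. Compound 2 has the lower of these two numbers, but the gap to compound 1 lies within the scatter of repeated measurements, so the two cannot be told apart on potency.

Compound 3, `CSc1cnc(-c2ccccc2C(C)C)nc1NCc1ccc(-c2cccnc2)cc1`, has not yet been measured. It differs from compound 2 in a single place: methylsulfanyl in place of fluoro on an aromatic carbon of the six-membered aromatic ring with two nitrogens, para to the 2-isopropylphenyl group. For the measured compounds named here, no pair of measured compounds shows what such a swap does here, so the expected step from compound 2 to compound 3 is a 1.5-fold higher number from compound 2 to compound 3 (0.16 log units; within the scatter), a change that may stay within the scatter. Compound 3 is therefore estimated at 160 nM in this assay, with a plausible range from 50 nM to 500 nM.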

Compound 3, half-maximal inhibitory concentration: 110 nM
Beside the measured number, compound 3's estimate is 1.5-fold (0.16 log units) above it; the range from low to high includes it.
By their numbers in this assay, from the lowest: compounds 2, 3 and 1 (each within the scatter of the next).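

Placing methylsulfanyl in place of fluoro on this aromatic carbon, para to a 2-isopropylphenyl group, gives no change at the digits printed from compound 2 to compound 3 (within the scatter) in this assay. This is the first step shown at this position, and it indicates that potency here does not separate these two groups, even though methylsulfanyl carries more heavy atoms and one hydrogen-bond acceptor where fluoro counts none. No measurement shown explains why the two groups read alike.

On these data alone, it remains open whether this position would accept other kinds of group equally well, such as an amine, a carboxylic acid or a longer chain like butylsulfanyl. A single swap also cannot show whether the same change would behave alike if other parts of the molecule were different.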